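A few compounds are considered here, and "the series" means these few. Any claim that something is new, unique, unknown or untested is made for them only; others in the source may bear on it.

Compound 1 `COc1cc(C)[nH]c(=O)c1CNC(=O)c1c(C)n([C@H](C)C2CCN(C(=O)N(C)C)CC2)c2ccccc12` and compound 2 `COc1cc(C)[nH]c(=O)c1CNC(=O)c1c(C)n([C@H](C)C2CCN(C(=O)OC(C)C)CC2)c2ccccc12` differ only at the carbonyl carbon attached to the amide-type nitrogen in a ring. In an assay on isolated protein for inhibition of histone-lysine N-methyltransferase EZH2 (Homo sapiens), read by scintillation proximity assay and scintillation counting, with stated times of 30 min and 2 h (a higher number here means a weaker inhibitor, a lower number a stronger inhibitor), compound 1 gives 3.3 nM. Compound 2 reaches only a limit of this assay, giving < 1 nM. The step is an at least 3.3-fold lower number from compound 1 to compound 2 (0.51 log units; beyond the scatter), its end resting at the limit of < 1 nM in this assay, at which 1 of the 2 values shown sits. Compound 3 `COc1cc(C)[nH]c(=O)c1CNC(=O)c1c(C)n([C@H](C)C2CCN(C(=O)C(C)C)CC2)c2ccccc12` carries isopropyl in place of isopropoxy on a carbonyl carbon. Among the measured compounds shown here, only that one step bears on this change, and it leaves the true value of compound 2 open, so compound 3 is expected to stay close, an expected step of an at least 1.2-fold higher number from compound 2 to compound 3 (0.07 log units; that floor lies within the scatter). Compound 3 is estimated in this assay at 1.2 nM, within 0.3 nM to 5 nM.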

Compound 3, half-maximal inhibitory concentration: 2.5 nM
For compound 3 the middle estimate is 2.1-fold (0.32 log units) below the measured one, and the stated range covers the measured number.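

In this assay, isopropyl in place of isopropoxy on this carbonyl carbon gives an at least 2.5-fold higher number from compound 2 to compound 3 (0.39 log units; beyond the scatter), so the gain seen with isopropoxy is lost with isopropyl. Isopropyl in place of dimethylamino gives a 1.3-fold lower number from compound 1 to compound 3 (0.12 log units; within the scatter), which leaves isopropoxy as the only one of the three groups set apart from the others. Compound 2 stands at a limit of the assay, so its steps give only a floor: the limit of < 1 nM in this assay, at which 1 of the 3 values shown sits.

On these data alone, how far compound 2 lies past that limit remains open. Also open, as far as these compounds go, is whether a methoxy, tert-butoxy or cyclopropyl group on this carbonyl carbon would match isopropoxy or isopropyl.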